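Series notes: one methyl step at the assay limit

The source may report more compounds than this note shows. Statements on the series, on what has been measured and on what is new or still open speak of the compounds shown alone.

Measured compounds and values:
compound 1 `CCC(C)C1NC(=O)N(C2CCCCC2)C1=O`: > 100000 nM
compound 2 `CC(C)C(NC(=O)NO)C(=O)NC1CCCC1`: > 100000 nM
compound 3 `CC(C)C1NC(=O)N(C2CCCCC2)C1=O`: > 100000 nM

In a functional assay on HeLa cells (Homo sapiens) for inhibition (a lower number here means a stronger inhibitor, a higher number a weaker inhibitor), compound 1 gives > 100000 nM, a limit of the assay and not a number. In this assay compound 2 gives > 100000 nM, again a limit. Compound 3 gives > 100000 nM, also a limit. All three sit at the limit of > 100000 nM in this assay, at which 3 of the 3 values shown sit.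

The cores of compound 2 and compound 3 differ in a way that is not broken down here. From compound 3 to compound 1 the change is methyl in place of hydrogen on a saturated chain carbon, two bonds along the chain from a saturated ring carbon, and the step that the two limits leave unreadable from compound 3 to compound 1. Compound 4 `CCC(C)C(NC(=O)NO)C(=O)NC1CCCC1` arises from compound 2 by methyl in place of hydrogen on a saturated chain carbon, three bonds along the chain from an amide-type nitrogen and a carbonyl carbon, the same kind of change but at a different place: two bonds along the chain from a saturated ring carbon in one case, three bonds along the chain from an amide-type nitrogen and a carbonyl carbon in the other.

The expectation for compound 4 rests on compound 2 sitting at the limit of > 100000 nM in this assay, at which 3 of the 3 values shown sit. The expected step is a number no higher from compound 2 to compound 4 (the limit leaves the size open). In this assay compound 4 is expected at about 100000 nM, between 30000 nM and 300000 nM, most likely reported again only as a limit.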

Compound 4, half-maximal inhibitory concentration: > 100000 nM
Compound 4 was reported as a limit; the forecaster's own chance of this, stated with the estimate: 85%; the middle value sits exactly at the limit.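

No step can be read from compound 2 to compound 4, since both values are limits of the assay. The compounds shown leave open whether the added methyl changes inhibition at all, and what actual value any of them would give.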